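Trimming an Isopropoxy to a Methyl on the Sulfonamide Aryl

This account rests on a few compounds, and the source may have more. Where it says the series, first, only, none or still open, it means among the compounds named here.

Compound 2 `Cc1c(C(=O)NCCCN2CCN(C)CC2)c(-c2cccc(N3CCN(c4ccc(NS(=O)(=O)c5cccc(OC(C)C)c5)cc4)CC3)c2)c(-c2ccc(Cl)cc2)n1C` stands at the weak end of the three compounds measured in an assay for binding affinity to Apoptosis regulator Bcl-2 (Homo sapiens), read by fluorescence polarization, with a stated time of 2 h (a lower number here means a stronger inhibitor, a higher number a weaker inhibitor), where compound 2 gives 522 nM. Compound 1 `CCCn1c(C)c(C(=O)O)c(-c2cccc(N3CCN(c4ccc(NS(=O)(=O)c5ccc(N[C@H](CCN6CCC(O)CC6)CSc6ccccc6)c(S(=O)(=O)C(F)(F)F)c5)cc4)CC3)c2)c1-c1ccc(Cl)cc1` gives 7.5 nM, and compound 3 `Cc1c(C(=O)O)c(-c2cccc(N3CCN(c4ccc(NS(=O)(=O)c5ccc(N[C@H](CCN6CCC(C)(O)CC6)CSc6ccccc6)c(S(=O)(=O)C(F)(F)F)c5)cc4)CC3)c2)c(-c2ccc(Cl)cc2)n1C` gives 4.6 nM; both numbers lie far below that of compound 2, well beyond the scatter. Compound 4 `Cc1cccc(S(=O)(=O)Nc2ccc(N3CCN(c4cccc(-c5c(C(=O)NCCCN6CCN(C)CC6)c(C)n(C)c5-c5ccc(Cl)cc5)c4)CC3)cc2)c1` differs from compound 2 by methyl in place of isopropoxy on an aromatic carbon. Within the data shown here, no measured pair isolates this change, so the expectation rests on compound 2 alone. Since a modest group is exchanged for a smaller one, the step from compound 2 to compound 4 is expected to be mild, most likely a slight weakening that may not exceed the scatter: the expected step is a 1.5-fold higher number from compound 2 to compound 4 (0.19 log units; within the scatter). Compound 4 is therefore estimated at 800 nM, with a range from 300 nM to 2500 nM.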

Compound 4, inhibition constant: 178 nM
Compound 4: middle estimate off by 4.5-fold (0.65 log units), on the high side; measured number outside the range, below it.
By their numbers in this assay, from the lowest: compounds 3 and 1 (each within the scatter of the next); then compound 4; then compound 2.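

In this assay, methyl in place of isopropoxy gives a 2.9-fold lower number from compound 2 to compound 4 (0.47 log units; beyond the scatter) and so shows that this position, meta to a large group, responds to the exchange, with the smaller group giving the lower number. Compounds 1 and 3 differ from compound 2 in more than one place and could not show this. Nothing shown explains the direction of the step.

As far as these compounds go, whether the step follows the loss of carbons or of the oxygen stays open, which a methoxy or an ethyl at this position would separate. Also open, from the compounds shown here alone, is whether it carries over to compounds with the carboxylic acid of compound 1.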